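Hydroxy for Methyl on the Pyrimidine of Compound 1

The source may report more compounds than this note shows. Statements on the series, on what has been measured and on what is new or still open speak of the compounds shown alone.

Measured compounds:
Compound 1: `Cc1cnc(N2CCC(c3coc4c(N5CCc6cc(S(C)(=O)=O)ccc65)ncnc34)CC2)nc1` — 252 nM
Compound 2: `CC(C)(C)OC(=O)N1CCC(c2coc3c(N4CC(C)(C)c5cc(S(C)(=O)=O)ccc54)ncnc23)CC1` — "not active" (no number reported), no number

Among the compounds with values here, compound 1 is the only compound with a number in a functional assay on cells for agonist activity at Glucose-dependent insulinotropic receptor (Homo sapiens), read by a luciferase reporter, with a stated time of 4 h (a lower number here means that less compound is needed, a higher number that more compound is needed for the effect), where compound 1 gives 252 nM. Within the data shown here, compound 2, which carries a different ring attached to the piperidine and a different saturated ring on the core, gives "not active" (no number reported) in this assay without a number, so it offers no scale for the step considered here.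

Compound 3 is `CS(=O)(=O)c1ccc2c(c1)CCN2c1ncnc2c(C3CCN(c4ncc(O)cn4)CC3)coc12`. It differs from compound 1 by hydroxy in place of methyl on an aromatic carbon. Among the measured compounds shown here, no pair of measured compounds shows this change, so its size is open. For the measured compounds named here, with only one number to rest on, the step in this assay is expected to be modest, and more likely toward a higher value than a lower one. Compound 3 is therefore estimated at 500 nM in this assay, with a range from 150 nM to 2000 nM, which means an expected step of a 2.0-fold higher number from compound 1 to compound 3 (0.30 log units; within the scatter).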

Compound 3, half-maximal effective concentration: 391 nM
Beside the measured number, compound 3's estimate is 1.3-fold (0.11 log units) above it; measured number inside the range.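

In this assay, the change from 5-methylpyrimidin-2-yl to 5-hydroxypyrimidin-2-yl gives a 1.6-fold higher number from compound 1 to compound 3 (0.19 log units; within the scatter), so the two compounds cannot be told apart at this position. Within the data shown here, this is the first reading of this position, and it shows that hydroxy, which brings a hydrogen-bond donor and a hydrogen-bond acceptor that methyl lacks, leaves the number within the scatter of that for methyl. No measurement shown here accounts for this result.

Going by these compounds, whether an amine, a methoxy group or a carboxylic acid on this aromatic carbon would also stay within the scatter remains open. So does whether a longer chain such as ethyl would do so, and a single pair cannot show whether the same exchange would behave alike on another core.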